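Working notes: from compound 1 to compound 4

The compounds below may be only part of what the source reports. "The series", "measured", "known", "first", "only" and "open" are said of these compounds alone.

Measured compounds:
compound 1, `COc1ccc([C@@H]2CC(=O)c3c(O)cc(OCc4cn(Cc5ccccc5F)nn4)cc3O2)cc1O`, 7320 nM
compound 2, `COc1ccc([C@@H]2CC(=O)c3c(O)cc(OCc4cn(Cc5ccc(Cl)cc5)nn4)cc3O2)cc1O`, 17800 nM
compound 3, `COc1ccc([C@@H]2C/C(=N\O)c3c(O)cc(OCc4cn(Cc5ccccc5F)nn4)cc3O2)cc1O`, 5710 nM

In a functional assay on RAW264.7 cells (Mus musculus) for inhibition, read by Griess assay, with stated times of 2 h and 24 h (a lower number here means a stronger inhibitor, a higher number a weaker inhibitor), compound 1 gives 7320 nM. Among the three numbers compound 1 sits in the middle: compound 3 gives 5710 nM, a gap within the scatter, so nothing separates the two; compound 2 gives 17800 nM, a gap beyond the scatter. For the measured compounds named here, the only single-point step so far is a 2.4-fold higher number from compound 1 to compound 2 (0.39 log units; beyond the scatter), which came with 4-chlorophenyl in place of 2-fluorophenyl on a saturated chain carbon bound to an aromatic nitrogen.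

Compound 4, `COc1ccc([C@@H]2CC(=O)c3c(O)cc(OCc4cn(CC5CC5)nn4)cc3O2)cc1O`, is not yet measured. It differs from compound 1 by cyclopropyl in place of 2-fluorophenyl on a saturated chain carbon bound to an aromatic nitrogen; cut one bond further out, 2-fluorobenzyl becomes cyclopropylmethyl. The change sits at the same place as the step from compound 1 to compound 2, but that step exchanged one aryl group for another, whereas here the aromatic ring leaves altogether, so it bears only loosely on the case. That step shows the position tolerates a change with a modest loss, so a small loss or no step beyond the scatter is expected in this assay , with the wide range reflecting the lack of a closer precedent. The expected step is a 1.3-fold higher number from compound 1 to compound 4 (0.11 log units; within the scatter). Compound 4 is estimated at 9500 nM, between 3500 nM and 26000 nM.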

Compound 4, half-maximal inhibitory concentration: 11900 nM
For compound 4 the middle estimate is 1.3-fold (0.10 log units) below the measured one; measured number inside the range.
By their numbers in this assay, from the lowest: compounds 3, 1, 4 and 2 (each within the scatter of the next, the first and the last beyond it).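

In this assay, for the compounds shown here, the aromatic ring proves dispensable at this place on a saturated chain carbon bound to an aromatic nitrogen: replacing 2-fluorobenzyl with cyclopropylmethyl gives a 1.6-fold higher number from compound 1 to compound 4 (0.21 log units; within the scatter) and removes a six-membered aromatic ring of carbon only in favour of a three-membered non-aromatic one, so the earlier aryl-for-aryl exchange is no longer the only kind of change read here. The same substituent also gives a 1.5-fold lower number from compound 2 to compound 4 (0.17 log units; within the scatter), which leaves compound 4 separated from neither aryl compound even though a 2.4-fold higher number from compound 1 to compound 2 (0.39 log units; beyond the scatter) does separate those two, so cyclopropylmethyl does not order itself relative to either of them in this assay. No supporting measurement bears on this result, and the numbers alone give no explanation for it.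

The compounds shown leave open how a chain ending in an amine or a carboxylic acid, or a longer straight alkyl chain such as n-hexyl, would read at this place. They also leave open whether the oxime of compound 3 would give a similar number when paired with cyclopropylmethyl rather than 2-fluorobenzyl.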